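A few compounds are considered here, and "the series" means these few. Any claim that something is new, unique, unknown or untested is made for them only; others in the source may bear on it.

Measured so far:
compound 1 `CC(C)n1ncnc1-c1ccccc1NCC1=NCCN1` — 104%
compound 2 `Cc1nc(-c2ccccc2NCC2=NCCN2)n(C)n1` — 98%
compound 3 `c1ccc(-c2nc[nH]n2)c(NCC2=NCCN2)c1` — 135%

In a functional assay with Alpha-1A adrenergic receptor (Homo sapiens) as the target, read by calcium flux (a higher number here means a larger maximal response, a lower number a smaller maximal response), compound 3 gives 135%, the highest of the three numbers. The nearest of the others is compound 1 with 104%, a gap beyond the usual scatter; the furthest is compound 2 with 98%, also beyond the scatter. Among the measured compounds shown here, no pair of measured compounds differs in one place, so no single step can be read from these three.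

Compound 4 `Cn1cccc1-c1ccccc1NCC1=NCCN1` has not yet been measured in this assay. It differs from compound 3 in one place: 1-methyl-1H-pyrrol-2-yl in place of 1H-1,2,4-triazol-3-yl on an aromatic carbon. For the measured compounds named here, since both compound 1 and compound 2 sit well below compound 3, and the change removes the one group that sets compound 3 apart, the account expects the maximal response to fall from compound 3 to compound 4, by a step of moderate size, a number 35 percentage points lower from compound 3 to compound 4 (beyond the scatter). Compound 4 is estimated to give 100% in this assay, within a range of 75% to 130%.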

Compound 4, largest response reached (reported as maximal response), in percent of the reference or control that the assay uses: 103%
Beside the measured number, compound 4's estimate is 3 percentage points below it, within the range that was stated.
By their numbers in this assay, from the lowest: compounds 2, 4 and 1 (each within the scatter of the next); then compound 3.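

In this assay, among the compounds shown here, the change from 1H-1,2,4-triazol-3-yl to 1-methyl-1H-pyrrol-2-yl on this aromatic carbon gives the first single step that can be read, a number 32 percentage points lower from compound 3 to compound 4 (beyond the scatter), and it is a large one. The maximal response therefore depends strongly on which five-membered aromatic ring occupies this place, although the change alters several counted features at once: the heavy atoms, the hetero atoms, and the hydrogen-bond donors and acceptors. Nothing at hand shows which of these differences accounts for the step.

For the compounds shown here, the single step cannot separate the loss of the hydrogen-bond donor from the loss of ring nitrogen atoms or the gain of the methyl group. Going by these compounds, how an unsubstituted 1H-pyrrol-2-yl group, a carboxylic acid or an amine would behave on this aromatic carbon remains open.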